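The source may report more compounds than this note shows. Statements on the series, on what has been measured and on what is new or still open speak of the compounds shown alone.

Measured in a functional assay (aorta) with Rattus norvegicus as the target; on this read-out lower numbers stand for an effect already at smaller amounts and higher numbers for an effect only at larger amounts of compound:
compound 1 `O=C1CCCN1C1=CC(CF)(CF)Oc2ccc([N+](=O)[O-])cc21`: 7.76 nM
compound 2 `O=C1CCCN1C1=CC(CF)(CF)Oc2ccc(C(F)(F)C(F)(F)F)cc21`: 1.51 nM
compound 3 `O=c1ccccn1[C@@H]1c2cc([N+](=O)[O-])ccc2OC(CF)(CF)[C@H]1O`: 28.8 nM

Compound 3 shows the highest number of the three. The difference between the core of compound 3 and the core of compound 1 is not broken down here. Between compound 1 and compound 2 the single change is 1,1,2,2,2-pentafluoroethyl in place of nitro on an aromatic carbon; it gave a 5.1-fold lower number from compound 1 to compound 2 (0.71 log units; beyond the scatter). Compound 4 `O=c1ccccn1[C@@H]1c2cc(C(F)(F)C(F)(F)F)ccc2OC(CF)(CF)[C@H]1O` is not yet measured; it carries the same change on the core of compound 3, (1,1,2,2,2-pentafluoroethyl in place of nitro on an aromatic carbon), at a place described in the same words. For compound 4 a step of about the earlier size is expected, a 4.4-fold lower number from compound 3 to compound 4 (0.65 log units; beyond the scatter). This expectation rests on one example only, the step from compound 1 to compound 2 of a 5.1-fold lower number from compound 1 to compound 2 (0.71 log units; beyond the scatter). For compound 4 the estimate in this assay is 6.5 nM, within a range from 2.5 nM to 18 nM.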

Compound 4, half-maximal effective concentration: 12 nM
For compound 4 the middle estimate is 1.8-fold (0.27 log units) below the measured one, and the stated range covers the measured number.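

On the core of compound 3, 1,1,2,2,2-pentafluoroethyl in place of nitro again lowers the number in this assay (a 2.4-fold lower number from compound 3 to compound 4 (0.38 log units; beyond the scatter)). The step keeps its direction on the second core, and its size cannot be told apart from the earlier one: the same change on two cores in this assay, a 5.1-fold lower number (0.71 log units; beyond the scatter) from compound 1 to compound 2 and a 2.4-fold lower number (0.38 log units; beyond the scatter) from compound 3 to compound 4, 2.1-fold (0.33 log units) apart, within the scatter of two such steps. This supports carrying the change between these two cores only; two pairs do not show that it would hold on any other core, and they do not explain the step.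

Still open, as far as these compounds go, is how a nitrile, an amine or a carboxylic acid on the same aromatic carbon would read in this assay. The contribution of the difference between the two cores also remains unresolved.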